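The compounds below may be only part of what the source reports. "The series", "measured", "known", "first", "only" and "open" are said of these compounds alone.

Measured compounds:
compound 1 `CCN(CC)C(=O)N1CCN(/[N+]([O-])=N/Oc2cc(O/N=[N+](\[O-])N(C)C)c([N+](=O)[O-])cc2[N+](=O)[O-])CC1`, 4900 nM
compound 2 `CN(C)/[N+]([O-])=N/Oc1cc(O/N=[N+](\[O-])N2CCCCC2)c([N+](=O)[O-])cc1[N+](=O)[O-]`, 4900 nM
compound 3 `CC1CCCCN1/[N+]([O-])=N/Oc1cc(O/N=[N+](\[O-])N(C)C)c([N+](=O)[O-])cc1[N+](=O)[O-]`, 4900 nM

In a functional assay on HL-60 cells (Homo sapiens) for antiproliferative activity, read by MTT assay, with a stated time of 72 h (a higher number here means a weaker inhibitor of growth, a lower number a stronger inhibitor of growth), compound 1 gives 4900 nM, compound 2 gives 4900 nM and compound 3 gives 4900 nM. For the measured compounds named here, compound 3 thus stands level with both of the others, and the only measured step that changes one place, no change at the digits printed from compound 2 to compound 3 (within the scatter), is within the scatter.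

Compound 4 `CCN(CC)/[N+]([O-])=N/Oc1cc(O/N=[N+](\[O-])N(C)C)c([N+](=O)[O-])cc1[N+](=O)[O-]` has not been measured. It differs from compound 3 by diethylamino in place of 2-methylpiperidin-1-yl on a double-bonded nitrogen. Going by the values given here, no measured step exchanges a ring on this nitrogen for an open chain, so the expectation rests on what is at hand: all three measured compounds sit at the same value, and the one variation made at this nitrogen, no change at the digits printed from compound 2 to compound 3 (within the scatter), left the result unchanged.

On that basis compound 4 is expected to stay within the scatter of compound 3, a step of no change at the digits printed from compound 3 to compound 4 (within the scatter). The estimate for compound 4 in this assay is 4900 nM, with a range from 2000 nM to 12000 nM.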

Compound 4, concentration for total growth inhibition: 2300 nM
Compound 4: middle estimate off by 2.1-fold (0.33 log units), on the high side; low and high end bracket the measured number.
By their numbers in this assay, from the lowest: compound 4; then compounds 1, 2 and 3 (each within the scatter of the next).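

In this assay, this double-bonded nitrogen proved able to shift the result, which the methyl on the saturated ring had not shown: diethylamino in place of 2-methylpiperidin-1-yl gives a 2.1-fold lower number from compound 3 to compound 4 (0.33 log units; beyond the scatter) and diethylamino in place of piperidin-1-yl gives a 2.1-fold lower number from compound 2 to compound 4 (0.33 log units; beyond the scatter). Both steps are modest, but they agree, and each replaces a ring at this nitrogen with an open chain. Nothing at hand gives a reason for the shift.

From the compounds shown here alone, what remains open is whether opening the ring matters in itself or whether the gain belongs to diethylamino alone, which a dipropylamino or a pyrrolidin-1-yl group at this nitrogen would help to separate. Going by these compounds, it is also open whether the same exchange would count for as much in place of the dimethylamino group that all these compounds share.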